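The source may hold more compounds than are shown below. What is called first, only, known or untested is meant among the compounds shown, and "the series" means these compounds.

Measured in an ADME assay on microsomes from liver (Homo sapiens) for metabolic stability; on this read-out lower numbers stand for a shorter-lived compound and higher numbers for a longer-lived compound:
- compound 1 `COc1cc(OCc2cccc(-c3ccc(C#N)cn3)c2)c2cc(-c3cn4nc(OC)sc4n3)oc2c1`: 1.57 h
- compound 2 `COc1cc(OCc2cccc(OCc3ccccc3)c2)c2cc(-c3cn4nc(OC)sc4n3)oc2c1`: 1.43 h

Compound 2 stands at 1.43 h, which cannot be told apart from compound 1 at 1.57 h. Compound 3 `COc1ccc(-c2cccc(COc3cc(OC)cc4oc(-c5cn6nc(OC)sc6n5)cc34)c2)nc1` differs from compound 2 in one place: 5-methoxypyridin-2-yl in place of benzyloxy on an aromatic carbon. Within the data shown here, only one measured step bears on this, a similar exchange of a pyridinyl group and benzyloxy: a 1.1-fold lower number from compound 1 to compound 2 (0.04 log units; within the scatter). That step suggests little change in this assay, so the expected step is a 1.0-fold lower number from compound 2 to compound 3 (0.01 log units; within the scatter), nothing beyond the scatter. For compound 3 the estimated half-life is 1.4 h, with an expected range of 0.8 h to 2.4 h.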

Compound 3, half-life: 0.767 h
Beside the measured number, compound 3's estimate is 1.8-fold (0.26 log units) above it; the measured number lies below the stated range.
By their numbers in this assay, from the lowest: compounds 3, 2 and 1 (each within the scatter of the next, the first and the last beyond it).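

In this assay, among these compounds, methoxy in place of cyano on an aromatic carbon gives the only step here that goes beyond the scatter, and only modestly (a 2.0-fold lower number from compound 1 to compound 3 (0.31 log units; beyond the scatter)). Exchanging benzyloxy for 5-methoxypyridin-2-yl stays within the scatter (a 1.9-fold lower number from compound 2 to compound 3 (0.27 log units; within the scatter)), so the group on the pyridine ring shows a clearer effect than that exchange does. No measurement here explains the difference between methoxy and cyano.

As far as these compounds go, whether an amine or a fluorine in place of the methoxy would give a longer or a shorter half-life remains open.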